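The source may hold more compounds than are shown below. What is called first, only, known or untested is meant among the compounds shown, and "the series" means these compounds.

Measured so far:
Compound 1, `CCN(CC)S(=O)(=O)c1ccc(S(=O)(=O)N2CCC[C@@H](C(=O)N[C@H]3CC[C@H](OC)CC3)C2)cc1`: in a functional assay on MIA PaCa-2 cells (Homo sapiens) for inhibition, read by MTT assay, with a stated time of 7 days (on this read-out higher numbers stand for weaker inhibition and lower numbers for stronger inhibition), compound 1 gives 1350 nM.
Compound 2, `CCN(CC)S(=O)(=O)c1ccc(S(=O)(=O)N2CCC[C@@H](C(=O)N3CCC(O)CC3)C2)cc1`: in this assay compound 2 gives 870 nM.
Compound 3, `CCN(CC)S(=O)(=O)c1ccc(S(=O)(=O)N2CCC[C@@H](C(=O)N[C@H]3CC[C@@H](OC)CC3)C2)cc1`: in this assay compound 3 gives 960 nM.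

All three compounds share the same core and differ only in the group attached to the carbonyl at one end. Compound 3 sits in the middle of this narrow spread: its nearest neighbour is compound 2, and the step of a 1.1-fold higher number from compound 2 to compound 3 (0.04 log units; within the scatter), while the step of a 1.4-fold lower number from compound 1 to compound 3 (0.15 log units; within the scatter) is also within the scatter. Compound 1 and compound 3 differ only in drawn configuration (the fact that compounds 1 and 3 differ only in the configuration as drawn), and even that change moved the number little. The step of a 1.6-fold lower number from compound 1 to compound 2 (0.19 log units; within the scatter) shows that exchanging the whole amide substituent likewise stayed within the scatter.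

Compound 4, `CCN(CC)S(=O)(=O)c1ccc(S(=O)(=O)N2CCC[C@@H](C(=O)N[C@@H]3CCOC3)C2)cc1`, carries a different group on the amide nitrogen: oxolan-3-yl in place of 4-methoxycyclohexyl on an amide-type nitrogen. Both measured exchanges at this position, from compound 1 to compound 2 and from compound 2 to compound 3, stayed within the scatter, so for compound 4 no step beyond the scatter is expected in this assay; the expected change is a 1.3-fold higher number from compound 3 to compound 4 (0.10 log units; within the scatter). Compound 4 is therefore estimated to give 1200 nM, with a likely range from 500 nM to 3000 nM.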

Compound 4, half-maximal inhibitory concentration: 750 nM
Beside the measured number, compound 4's estimate is 1.6-fold (0.20 log units) above it; the range from low to high includes it.
By their numbers in this assay, from the lowest: compounds 4, 2, 3 and 1 (each within the scatter of the next).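

The group on the amide-type nitrogen can shrink from 4-methoxycyclohexyl, with 8 heavy atoms and a six-membered ring of carbon only, to oxolan-3-yl, with 5 heavy atoms and a five-membered ring holding 1 hetero atom, and this assay still shows no step beyond the scatter: a 1.3-fold lower number from compound 3 to compound 4 (0.11 log units; within the scatter). The exchange can also be read from a second starting point, a 1.8-fold lower number from compound 1 to compound 4 (0.26 log units; within the scatter), and from the differently attached 4-hydroxypiperidin-1-yl, a 1.2-fold lower number from compound 2 to compound 4 (0.06 log units; within the scatter), so all four compounds now lie within the scatter of one another, even though the ring size, the ring atoms and the number of stereocentres all differ. The two readings of the same exchange are not simple repeats, and both stay within the scatter, so neither drawn form of the 4-methoxycyclohexyl group sets the outcome apart: the fact that compounds 1 and 3 differ only in the configuration as drawn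

These compounds leave open whether any group at this position can move the number beyond the scatter, for example a phenyl ring, a carboxylic acid, a primary amine or a longer chain such as n-hexyl. They also leave open how the opposite configuration of the oxolan-3-yl group would read.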